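The compounds below may be only part of what the source reports. "The series", "measured", "known", "first", "only" and "open" are said of these compounds alone.

Values so far in a physicochemical assay for solubility, at pH 1.1 (a lower number here means a less soluble compound, a higher number a more soluble compound), are:
- compound 1 `Cc1cc(CN(CC2CC2)[C@@H](CC(=O)O)c2ccc(Cl)cc2)ccc1OCCN1C(=O)CCC1=O` with 3000000 nM
- compound 2 `Cc1cc(CN(CC2CCCC2)C(CC(=O)O)c2ccc(Cl)cc2)ccc1OCCN1C(=O)CCC1=O` with 3000000 nM

Compound 2 stands level with compound 1 at the digits available, and the two values lie within the scatter of each other.

Compound 3 `Cc1cc(CN(CC2CCCC2)[C@@H](CC(=O)O)c2ccc(Cl)cc2)ccc1OCCN1C(=O)CCC1=O` is still unmeasured. Its difference from compound 2 is the two compounds have the same atoms and bonds; at least one stereo element is drawn with a configuration in one of them and without one in the other: 1 of 1 stereo elements differ; a stereocentre at a saturated chain carbon is drawn without a configuration in compound 2 and S in compound 3 and in words the two compounds have the same atoms and bonds, with a stereocentre at a saturated chain carbon drawn without a configuration in compound 2 and S in compound 3.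

Going by the values given here, the series holds no measured pair that differs in one place, so there is no direct guide to the size of this step. With atoms and bonds unchanged, no step beyond the scatter is expected in this assay in either direction. This expectation rests on compound 2 at 3000000 nM and on nothing more specific. The expected change is no change at the digits printed from compound 2 to compound 3 (within the scatter) and is estimated to stay within the scatter. Compound 3 is estimated at 3000000 nM (expected range 1500000 nM to 5000000 nM).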

Compound 3, solubility: 3000000 nM
The estimate for compound 3 equals the measured number at the digits printed; low and high end bracket the measured number.
By their numbers in this assay, from the lowest: compounds 1, 2 and 3 (each within the scatter of the next).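

In this assay, going by these compounds alone, the S configuration drawn at the saturated chain carbon gives no change at the digits printed from compound 2 to compound 3 (within the scatter), the first reading of this stereocentre. With that configuration drawn in both compounds, cyclopentyl in place of cyclopropyl gives no change at the digits printed from compound 1 to compound 3 (within the scatter), so the series now has a single-place comparison for the ring on this chain carbon, and the two ring sizes shown cannot be told apart in this assay. The stereo step supports only a limited reading, and its scope is set by what separates the two drawings: the fact that one of compounds 2 and 3 is drawn with a defined configuration and the other without, at the place where they differ

Neither step shows whether the R configuration at this carbon would read apart from the S configuration, since only a defined S form and a drawing without a configuration are compared. From the compounds shown here alone, it also remains open whether a group of another kind in place of the ring, such as a longer alkyl chain or a chain carrying an amine, would move the number in this assay, as both steps here stay within the scatter.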